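Carbonyl substituent variation on the furanyl core

The source may report more compounds than this note shows. Statements on the series, on what has been measured and on what is new or still open speak of the compounds shown alone.

Measured compounds:
compound 1 `CCCOC(=O)C1=C(C)NC(=O)NC1c1ccoc1` with 50%
compound 2 `CCN(CC)C(=O)C1=C(C)NC(=O)NC1c1ccoc1` with 15%
compound 3 `CC1=C(C(=O)SC(C)C)C(c2ccoc2)NC(=O)N1` with 9%

In an assay on membranes from CHO cells for displacement of a labelled ligand from adenosine receptor A1 (Homo sapiens), read by scintillation counting, with a stated time of 60 min, tested at 1 uM (on this read-out lower numbers stand for less inhibition and higher numbers for more inhibition at the one concentration tested (going by the name of the read-out)), compound 1 gives 50%, compound 2 gives 15% and compound 3 gives 9%. Compound 3 is the lowest of the three numbers. Its gap to compound 2 lies within the scatter, a number 6 percentage points lower from compound 2 to compound 3 (within the scatter), so the two cannot be ordered. Its gap to compound 1 is beyond the scatter, a number 41 percentage points lower from compound 1 to compound 3 (beyond the scatter).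

Compound 4 `CC1=C(C(=O)OC2CCCCC2)C(c2ccoc2)NC(=O)N1` differs from compound 3 in one place: cyclohexyloxy in place of isopropylsulfanyl on a carbonyl carbon. For the measured compounds named here, the step that bears most directly on this change is the one from compound 1 to compound 3, a number 41 percentage points lower from compound 1 to compound 3 (beyond the scatter), which introduced isopropylsulfanyl on the carbonyl carbon in place of an alkoxy group and was large. The step of a number 35 percentage points lower from compound 1 to compound 2 (beyond the scatter) was likewise large when propoxy was replaced. Both point to an alkoxy group on the carbonyl carbon as the variant with the higher reading. Going by the values given here, no measured pair compares cyclohexyloxy with propoxy, so the effect of the larger ring-bearing alkoxy group itself is untested.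

On this basis compound 4 is expected to move upward from compound 3 by a number 31 percentage points higher from compound 3 to compound 4 (beyond the scatter), beyond the scatter. The estimate for compound 4 in this assay is 40%, with a range from 15% to 65%.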

Compound 4, a percentage reported as inhibition, at one concentration (the size of the read-out at that concentration, not a potency): 15%
The estimate for compound 4 lay 25 percentage points above the measured number; the range from low to high includes it.
By their numbers in this assay, from the lowest: compounds 3, 2 and 4 (each within the scatter of the next); then compound 1.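

Keeping an oxygen on the carbonyl carbon does not by itself hold the reading in this assay: cyclohexyl in place of propyl gives a number 35 percentage points lower from compound 1 to compound 4 (beyond the scatter), a large step within the alkoxy groups themselves. Cyclohexyloxy cannot be told apart from either of the other two replacements, with a number 6 percentage points higher from compound 3 to compound 4 (within the scatter) against isopropylsulfanyl and no change at the digits printed from compound 2 to compound 4 (within the scatter) against diethylamino, so among the four groups on this carbonyl carbon only the propoxy of compound 1 stands apart. Nothing measured in this set explains the difference between propoxy and cyclohexyloxy.

Going by these compounds, with only these two alkoxy groups in hand, it remains open whether the reading of compound 1 belongs to propoxy alone or extends to other groups attached through oxygen. Isopropoxy would set oxygen directly against the sulfur of the isopropylsulfanyl group in compound 3, while butoxy as a longer chain and cyclopentyloxy as a smaller ring would fill the span between propoxy and cyclohexyloxy.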